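This account rests on a few compounds, and the source may have more. Where it says the series, first, only, none or still open, it means among the compounds named here.

Measured in a functional assay on Ehrlich cells (Mus musculus) for cytotoxicity, tested at 25 ug/mL; on this read-out lower numbers stand for a weaker effect and higher numbers for a stronger effect at the one concentration tested:
- compound 1 `COc1cc(N2C(N)=C(C#N)C(c3cccc([N+](=O)[O-])c3)C3=C2CC(C)(C)CC3=O)cc(OC)c1OC`: 20%
- compound 2 `COc1cc(N2C(N)=C(C#N)C(c3cccs3)C3=C2CC(C)(C)CC3=O)cc(OC)c1OC`: 10%
- compound 3 `COc1ccc(C2C(C#N)=C(N)N(c3cc(OC)c(OC)c(OC)c3)C3=C2C(=O)CC(C)(C)C3)cc1`: 1%

Compound 3 gives the smallest of the three numbers. Its step from compound 2, a number 9 percentage points lower from compound 2 to compound 3 (within the scatter), does not separate the two, whereas a number 19 percentage points lower from compound 1 to compound 3 (beyond the scatter) does, though only modestly.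

Compound 4 `COc1cc(N2C(N)=C(C#N)C(c3ccc(C)o3)C3=C2CC(C)(C)CC3=O)cc(OC)c1OC` differs from compound 3 in one place: 5-methylfuran-2-yl in place of 4-methoxyphenyl on a saturated ring carbon. All three measured steps are likewise exchanges of the group on that saturated ring carbon. Two of them, a number 10 percentage points lower from compound 1 to compound 2 (within the scatter) and a number 9 percentage points lower from compound 2 to compound 3 (within the scatter), lie within the scatter; only a number 19 percentage points lower from compound 1 to compound 3 (beyond the scatter) is beyond it. The one earlier case of a five-membered aromatic ring with one hetero atom at this position, compound 2, sits within the scatter of compound 3. The expectation for compound 4 is therefore a step of a number 6 percentage points higher from compound 3 to compound 4 (within the scatter), upward if anything but not beyond the scatter. Compound 4 is estimated at 7% in this assay, with a range from 0% to 18%.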

Compound 4, a percentage reported as activity, at one concentration (the size of the read-out at that concentration, not a potency): 31%
For compound 4 the middle estimate is 24 percentage points below the measured one; measured number above the stated range.
By their numbers in this assay, from the lowest: compounds 3, 2 and 1 (each within the scatter of the next, the first and the last beyond it); then compound 4.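

In this assay, 5-methylfuran-2-yl on the saturated ring carbon gives a number 30 percentage points higher from compound 3 to compound 4 (beyond the scatter), a number 21 percentage points higher from compound 2 to compound 4 (beyond the scatter) and a number 11 percentage points higher from compound 1 to compound 4 (beyond the scatter), so compound 4 stands highest of the four, with every step modest but beyond the scatter. A five-membered aromatic ring with one hetero atom does not by itself set the number at this position: compound 2 carries such a ring and stays within the scatter of compound 3, so the identity of the ring and its substituent matters here. Nothing available explains the rise in compound 4.

Open, going by these compounds, is whether the step belongs to the furan oxygen or to the methyl, which furan-2-yl without the methyl or 5-ethylfuran-2-yl would help separate. On these data alone, with readings at a single concentration, the potency of compound 4 also remains open.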